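Xanthine series: aryl group on the piperazine nitrogen

The source may report more compounds than this note shows. Statements on the series, on what has been measured and on what is new or still open speak of the compounds shown alone.

Measured so far:
compound 1 `CC#CCn1c(N2CCC[C@@H](N)C2)nc2c1c(=O)n(CCCN1CCN(c3noc(-c4ccccc4)n3)CC1)c(=O)n2C` — 1450 nM
compound 2 `CC#CCn1c(N2CCC[C@@H](N)C2)nc2c1c(=O)n(CCCN1CCN(c3nc(-c4ccccc4)ns3)CC1)c(=O)n2C` — 1930 nM

In a functional assay on HEK293 cells for agonist activity at Glucose-dependent insulinotropic receptor (Homo sapiens), read by a luciferase reporter (a lower number here means that less compound is needed, a higher number that more compound is needed for the effect), compound 2 gives the highest of the two numbers, its nearest neighbour being compound 1. For the measured compounds named here, the only step recorded, a 1.3-fold higher number from compound 1 to compound 2 (0.12 log units; within the scatter), exchanges one five-membered heteroaryl for another and stays within the scatter.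

Compound 3 `CC#CCn1c(N2CCC[C@@H](N)C2)nc2c1c(=O)n(CCCN1CCN(c3ncc(CC)cn3)CC1)c(=O)n2C` carries the change (5-ethylpyrimidin-2-yl in place of 3-phenyl-1,2,4-thiadiazol-5-yl on an amine nitrogen in a ring). Going by the values given here, no measured step covers a six-membered heteroaryl on this nitrogen, so the one step within the scatter is the only guide, and a step of no clear direction beyond the scatter is expected: a 1.0-fold higher number from compound 2 to compound 3 (0.02 log units; within the scatter). Compound 3 is estimated at 2000 nM, range 600 nM to 7000 nM.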

Compound 3, half-maximal effective concentration: 3990 nM
The estimate for compound 3 lay 2.0-fold (0.30 log units) below the measured number; low and high end bracket the measured number.
By their numbers in this assay, from the lowest: compounds 1 and 2 (each within the scatter of the next); then compound 3.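

In this assay, for the compounds shown here, 5-ethylpyrimidin-2-yl on this amine nitrogen gives the only steps beyond the scatter: a 2.1-fold higher number from compound 2 to compound 3 (0.32 log units; beyond the scatter), and a 2.8-fold higher number from compound 1 to compound 3 (0.44 log units; beyond the scatter). The number at this position therefore does respond to the group carried, though modestly, while the two phenyl-bearing five-membered heteroaryls stay within the scatter of each other. Nothing available explains the rise.

The ring and its substituent change together, so the step cannot be assigned to either one. A 5-phenylpyrimidin-2-yl or an unsubstituted pyrimidin-2-yl on this nitrogen would separate the two.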